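This account rests on a few compounds, and the source may have more. Where it says the series, first, only, none or still open, it means among the compounds named here.

Working notes on the series sharing the core of compound 1 `COc1cc(NC2=CC(=O)c3ncncc3C2=O)cc(OC)c1OC`. In a functional assay on BXPC-3 cells (Homo sapiens) for cytotoxicity, read by MTT assay, with a stated time of 72 h (on this read-out higher numbers stand for weaker inhibition and lower numbers for stronger inhibition), compound 1 gives 1600 nM. Compound 2 `COc1ccc(-c2ccc(NC3=CC(=O)c4ncncc4C3=O)cc2)cc1` gives 3500 nM, and compound 3 `COc1cccc(NC2=CC(=O)c3ncncc3C2=O)c1` gives 1800 nM. Compound 2 sits at the high end of the three numbers: compound 1 lies beyond the scatter below it, while compound 3 lies within the scatter of it, so no order between compound 2 and compound 3 can be read from these two values.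

Compound 4 `COc1ccc(NC2=CC(=O)c3ncncc3C2=O)cc1` has not yet been run in this assay. It differs from compound 2 in one place: methoxy in place of 4-methoxyphenyl on an aromatic carbon. Among the measured compounds shown here, no measured pair in the set shows this change directly, so the expectation rests on the spread of the three known numbers. Compound 3 also carries a single methoxy and gives 1800 nM. On that basis a small downward step is expected, a 1.8-fold lower number from compound 2 to compound 4 (0.24 log units; within the scatter), near the edge of the scatter rather than clearly beyond it. Compound 4 is therefore estimated at 2000 nM, with a range from 900 nM to 4500 nM.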

Compound 4, half-maximal inhibitory concentration: 1700 nM
Estimate against measurement, compound 4: 1.2-fold (0.07 log units) above; the measured number falls inside the stated range.
By their numbers in this assay, from the lowest: compounds 1, 4, 3 and 2 (each within the scatter of the next, the first and the last beyond it).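

In this assay, among the compounds shown here, replacing 4-methoxyphenyl with methoxy on this aromatic carbon gives a 2.1-fold lower number from compound 2 to compound 4 (0.31 log units; beyond the scatter), the first reading of a change in one place, and a modest one. The second aromatic ring is therefore not required at this position for a number in this range, and the larger group brings no gain here; compound 3 gives 1800 nM and compound 4 gives 1700 nM, which lie within the scatter of each other, so no effect of where the single methoxy sits can be read. Nothing available explains the step.

Still open, going by these compounds, is whether the number moves further with a hydroxyl, an amine or a fluorine at this place. A longer chain such as ethoxy or butoxy, which would show how the number tracks the size of the group between methoxy and 4-methoxyphenyl, is also untested in the compounds shown.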